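Compound 3 and its 4-acetylphenyl analogue

This account rests on a few compounds, and the source may have more. Where it says the series, first, only, none or still open, it means among the compounds named here.

In a functional assay on KYSE-410 cells (Homo sapiens) for antiproliferative activity, read by MTT assay, with a stated time of 72 h (on this read-out higher numbers stand for weaker inhibition and lower numbers for stronger inhibition), compound 1 (`COc1ccccc1NC(=O)c1ccnc2cc(Br)ccc12`) gives > 20000 nM as a limit, not a number. Compound 2 (`CC(C)(C)c1ccc(NC(=O)c2cc(=O)[nH]c3cc(Br)ccc23)cc1`) gives > 20000 nM as a limit too. Compound 3 (`O=C(Nc1cccc(F)c1)c1cc(=O)[nH]c2cc(-c3ccccc3)ccc12`) gives > 20000 nM as a limit as well. Compound 3 therefore has no number of its own and shares its position with the other two (the limit of > 20000 nM in this assay, at which 3 of the 3 values shown sit). Compound 4 (`CC(=O)c1ccc(-c2ccc3c(C(=O)Nc4cccc(F)c4)cc(=O)[nH]c3c2)cc1`) changes phenyl to 4-acetylphenyl (acetyl in place of hydrogen on an aromatic carbon). Among the compounds with values here, no measured pair shows the size of such a change. A small move towards stronger inhibition is expected (an at least 1.4-fold lower number from compound 3 to compound 4 (0.15 log units; that floor lies within the scatter)), and another limit reading would be no surprise. For compound 4 the estimate is 14000 nM at the middle, with 4000 nM to 25000 nM as the expected range.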

Compound 4, half-maximal inhibitory concentration: > 20000 nM
Compound 4: only a limit was reported (the forecaster's own chance of this, stated with the estimate: 60%); middle value at least 1.4-fold (0.15 log units) away from the limit.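

Compound 3 and compound 4 both give only a limit, so no step can be read between them: the limit of > 20000 nM in this assay, at which 4 of the 4 values shown sit.

The compounds shown leave open which change, if any, would give a measured number rather than a limit.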